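Methoxy on the Benzamide of a Thiophene Core

The compounds below may be only part of what the source reports. "The series", "measured", "known", "first", "only" and "open" are said of these compounds alone.

Compounds measured so far:
Compound 1, `CCOC(=O)c1sc2ccc(NCc3nc[nH]c3C)cc2c1NC(=O)c1ccccc1`: 23300 nM
Compound 2, `CCOC(=O)c1sc2ccc(NCc3nc[nH]c3C)cc2c1NC(=O)c1ccc(OC)cc1`: 8220 nM
Compound 3, `CCOC(=O)c1sc2ccc(N)cc2c1NC(=O)c1ccccc1`: > 50000 nM

Three compounds were tested in a functional assay on HeLa cells (Homo sapiens) for antiproliferative activity, read by MTT assay, with a stated time of 48 h; on this read-out higher numbers stand for weaker inhibition of growth and lower numbers for stronger inhibition of growth. Compound 1 gives 23300 nM in this assay, and compound 2 gives 8220 nM. The two differ by methoxy in place of hydrogen on an aromatic carbon, and this change makes a 2.8-fold lower number from compound 1 to compound 2 (0.45 log units; beyond the scatter).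

Compound 3 is measured only as a limit in this assay, > 50000 nM. Its value sits at the limit of > 50000 nM in this assay, at which 1 of the 3 values shown sits, so its step from compound 1, an at least 2.1-fold higher number from compound 1 to compound 3 (0.33 log units; beyond the scatter), is known only as a lower bound. Compound 3 differs from compound 1 by hydrogen in place of (5-methyl-1H-imidazol-4-yl)methyl on a nitrogen on an aromatic ring, and this is how the core of compounds 1 and 2 differs from the core of compounds 3 and 4.

Compound 4, `CCOC(=O)c1sc2ccc(N)cc2c1NC(=O)c1ccc(OC)cc1`, has not yet been measured in this assay. It differs from compound 3 by methoxy in place of hydrogen on an aromatic carbon. Among the compounds with values here, this is the same change as the one made from compound 1 to compound 2, on the same kind of place, and it has occurred once among the measured compounds. Because that change made a 2.8-fold lower number from compound 1 to compound 2 (0.45 log units; beyond the scatter), a step of about that size is expected here as well; the expected step is an at least 1.6-fold lower number from compound 3 to compound 4 (0.22 log units; that floor lies within the scatter). Since compound 3 is known only as a limit, the starting point is uncertain, and the result could itself be a limit. The estimate for compound 4 in this assay is 30000 nM, expected to lie between 8000 nM and 100000 nM.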

Compound 4, concentration for 50% growth inhibition: > 50000 nM
Compound 4 was reported as a limit (the forecaster's own chance of this, stated with the estimate: 35%); middle value at least 1.6-fold (0.22 log units) away from the limit.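

Compound 4 stands only as a limit in this assay, > 50000 nM. The methoxy change that lowered the number on the core of compound 1 cannot be read on the core of compound 3, as neither end of that step is a number, so the data neither confirm nor rule out that it carries over, and compound 3 and compound 4 now stand at the same limit: the limit of > 50000 nM in this assay, at which 2 of the 4 values shown sit. The other change can be read once more, and hydrogen in place of (5-methyl-1H-imidazol-4-yl)methyl on the nitrogen gives an at least 6.0-fold higher number from compound 2 to compound 4 (0.78 log units; beyond the scatter), which points the same way with the phenyl and the 4-methoxyphenyl amide, though the size of that effect cannot be compared between them: the same change on two cores in this assay, an at least 2.1-fold higher number (0.33 log units; beyond the scatter) from compound 1 to compound 3 and an at least 6.0-fold higher number (0.78 log units; beyond the scatter) from compound 2 to compound 4; the limit leaves it open whether they differ.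

The compounds shown leave open whether the methoxy change does anything at all without the (5-methyl-1H-imidazol-4-yl)methyl group, since only a core that gives a number in this assay could show it. They also leave open whether that group is needed as an imidazole, as a benzyl group on the same nitrogen would test, and how a chloro group in place of the methoxy or a carboxylic acid in place of the ethyl ester would read.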